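The source may hold more compounds than are shown below. What is called first, only, known or untested is meant among the compounds shown, and "the series" means these compounds.

Working notes on the series. Of the compounds shown here, two sharing one core have been measured so far. Compound 1 `C=CC(=O)Nc1ccc(-c2nc(Cl)cc(Nc3ccc(C(=O)Nc4cccc(C)c4)cc3)n2)cc1` in a functional assay on Raji cells (Homo sapiens) for antiproliferative activity, read by MTT assay, with a stated time of 48 h (a lower number here means a stronger inhibitor, a higher number a weaker inhibitor), gives 6980 nM. Compound 2 `C=CC(=O)Nc1ccc(-c2nc(Cl)cc(Nc3ccc(C(=O)N(C)C)cc3)n2)cc1` in this assay gives 42900 nM. Among the measured compounds shown here, compound 2 therefore stands at the higher of the two numbers, compound 1 being its only neighbour: the single step measured is a 6.1-fold higher number from compound 1 to compound 2 (0.79 log units; beyond the scatter). Compound 3 `C=CC(=O)Nc1ccc(-c2nc(Cl)cc(Nc3ccc(C(=O)Nc4cc(C)ccc4C)cc3)n2)cc1` is not yet measured. The change from compound 2 to compound 3 is (2,5-dimethylphenyl)amino in place of dimethylamino on a carbonyl carbon. For the measured compounds named here, the only measured step that bears on it is the one from compound 1 to compound 2, in which an arylamino group on the carbonyl carbon gave way to dimethylamino; the present change runs the other way, though the arylamino group entering is not the one that left compound 1. A fall in this assay of roughly that size is expected, as a 5.4-fold lower number from compound 2 to compound 3 (0.73 log units; beyond the scatter). Compound 3 is thus estimated at 8000 nM in this assay, with a range of 3000 nM to 25000 nM.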

Compound 3, half-maximal inhibitory concentration: 20900 nM
The estimate for compound 3 lay 2.6-fold (0.42 log units) below the measured number; the measured number falls inside the stated range.
By their numbers in this assay, from the lowest: compound 1; then compound 3; then compound 2.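

In this assay, the added methyl in place of hydrogen on an aromatic carbon gives a 3.0-fold higher number from compound 1 to compound 3 (0.48 log units; beyond the scatter), so the substitution on the aryl ring of the arylamino group affects the read-out, not merely the presence of that ring. Against dimethylamino, (2,5-dimethylphenyl)amino still gives a 2.1-fold lower number from compound 2 to compound 3 (0.31 log units; beyond the scatter), so both arylamino groups shown stand lower than dimethylamino, with compound 1 lower than compound 3. No measurement to hand accounts for the effect of the added methyl or for the order of the three compounds.

The compounds shown leave open how an unsubstituted phenylamino group, or a ring carrying a methoxy group or fluorine, would stand in this series. Also open, on these data alone, is whether a cyclic amine such as morpholine on the carbonyl carbon would stand nearer to compound 2 or to compound 1.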